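This account rests on a few compounds, and the source may have more. Where it says the series, first, only, none or still open, it means among the compounds named here.

Compound 1 `COc1cc(-c2nccn2C)cc(OC)c1OC` gives no number in a functional assay on MDA-MB-468 cells (Homo sapiens) for antiproliferative activity, read by MTT assay, with a stated time of 72 h; a higher number here means a weaker inhibitor, a lower number a stronger inhibitor: its value there, > 100000 nM, is a limit of the assay, so it can only be said to stand at or beyond that boundary (the limit of > 100000 nM in this assay, at which 1 of the 2 values shown sits). Compound 2 `COc1cccc(-n2ccnc2-c2cc(OC)c(OC)c(OC)c2)c1` is the one measured partner that differs from it in a single place, a 3-methoxyphenyl in place of methyl on an aromatic nitrogen; in this assay compound 2 gives 10400 nM. That exchange brought an at least 9.6-fold lower number from compound 1 to compound 2 (0.98 log units; beyond the scatter).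

Compound 3 `COc1cc(-c2nccn2-c2ccc(F)cc2)cc(OC)c1OC` makes a change of the same kind at the same ring nitrogen: 4-fluorophenyl in place of methyl on an aromatic nitrogen. Going by the values given here, only the step from compound 1 to compound 2 bears on it, and since that step was at least modest, a step of comparable size and in the same direction is expected here, so that compound 3 is estimated to show an at least 8.3-fold lower number from compound 1 to compound 3 (0.92 log units; beyond the scatter). Compound 3 is therefore expected to reach about 12000 nM, within a range from 3000 nM to 60000 nM.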

Compound 3, half-maximal inhibitory concentration: 62200 nM
The estimate for compound 3 lay 5.2-fold (0.71 log units) below the measured number; the measured number lies above the stated range.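

In this assay, putting a substituted phenyl ring on this ring nitrogen does not by itself secure the gain seen with compound 2: the exchange for 4-fluorophenyl gives an at least 1.6-fold lower number from compound 1 to compound 3 (0.20 log units; that floor lies within the scatter). What the ring carries matters, as going from 3-methoxyphenyl to 4-fluorophenyl at the same nitrogen brings a 6.0-fold higher number from compound 2 to compound 3 (0.78 log units; beyond the scatter). The true size of the step away from methyl remains unknown because compound 1 gives only a limit: the limit of > 100000 nM in this assay, at which 1 of the 3 values shown sits.

The two rings differ both in their substituent and in where it sits, so the compounds shown cannot separate the role of the methoxy group or the fluorine from that of its place on the ring. Also open, going by these compounds, is how a plain phenyl, a 3-fluorophenyl, a 4-methoxyphenyl or a phenyl ring bearing an amine would behave at this nitrogen.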